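Sulfonyl Substituents and Cytotoxicity on Macrophage Cells

A few compounds are considered here, and "the series" means these few. Any claim that something is new, unique, unknown or untested is made for them only; others in the source may bear on it.

Compound 1 `COc1cc(NC(=O)c2ccc(Cl)c([N+](=O)[O-])c2)ccc1NS(=O)(=O)C(F)(F)F`: > 250000 nM
Compound 2 `CS(=O)(=O)Nc1ccc(NC(=O)c2ccc(Cl)c([N+](=O)[O-])c2)cc1Cl`: 43600 nM
Compound 3 `CCS(=O)(=O)Nc1ccc(NC(=O)c2ccc(Cl)c([N+](=O)[O-])c2)cc1Cl`: 125000 nM

In an ADME assay on RAW264.7 cells (Mus musculus) for cytotoxicity, read by MTT assay, with a stated time of 48 h (a lower number here means a stronger inhibitor, a higher number a weaker inhibitor), compound 3 gives 125000 nM, the highest of the two numbers obtained. For the measured compounds named here, compound 2 gives 43600 nM in this assay; the single measured step is a 2.9-fold higher number from compound 2 to compound 3 (0.46 log units; beyond the scatter), a modest one. Compound 1 reaches only a limit of the assay, > 250000 nM, and not a number. Compound 4 `O=C(Nc1ccc(NS(=O)(=O)C(F)(F)F)c(Cl)c1)c1ccc(Cl)c([N+](=O)[O-])c1` has not yet been measured; it differs from compound 3 by trifluoromethyl in place of ethyl on a sulfonyl sulfur. Going by the values given here, no measured step covers this exact change. Among the compounds with values here, the one measured step, a 2.9-fold higher number from compound 2 to compound 3 (0.46 log units; beyond the scatter), goes to a higher number, and compound 1, which carries the same trifluoromethyl group, sits at the limit (the limit of > 250000 nM in this assay, at which 1 of the 3 values shown sits). Compound 4 is therefore expected to give 220000 nM (range 90000 nM to 600000 nM), a step of a 1.8-fold higher number from compound 3 to compound 4 (0.25 log units; within the scatter), quite possibly reported only as a limit.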

Compound 4, half-maximal inhibitory concentration: 31700 nM
The estimate for compound 4 lay 6.9-fold (0.84 log units) above the measured number; measured number below the stated range.
By their numbers in this assay, from the lowest: compounds 4 and 2 (each within the scatter of the next); then compound 3. At a limit, above all of these: compound 1.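

Trifluoromethyl in place of ethyl on the sulfonyl sulfur gives a 3.9-fold lower number from compound 3 to compound 4 (0.60 log units; beyond the scatter), and trifluoromethyl in place of methyl gives a 1.4-fold lower number from compound 2 to compound 4 (0.14 log units; within the scatter), so in this assay ethyl, not trifluoromethyl, stands apart among these three groups. With trifluoromethyl kept, chloro in place of methoxy on an aromatic carbon gives an at least 7.8-fold lower number from compound 1 to compound 4 (0.89 log units; beyond the scatter), which ties the high reading of compound 1 to the methoxy change rather than to trifluoromethyl. Compound 1 itself stands at a limit, not a number: the limit of > 250000 nM in this assay, at which 1 of the 4 values shown sits.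

From the compounds shown here alone, whether a longer chain such as propyl on the sulfonyl sulfur would follow ethyl remains open. So does the effect of an amine in place of chloro.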